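From bromo to carboxy on a shared core

The compounds below may be only part of what the source reports. "The series", "measured", "known", "first", "only" and "open" are said of these compounds alone.

Compound 1 `Cc1ccc2[nH]c(COc3cccc(OCC4CCOCC4)c3)c(C)c(=O)c2c1` value < 1000 nM
Compound 2 `Cc1c(COc2cccc(OCC3CCOCC3)c2)[nH]c2ccc(Br)cc2c1=O` value < 1000 nM

In a physicochemical assay for solubility, at pH 6.8 (on this read-out higher numbers stand for higher solubility and lower numbers for lower solubility), compound 2 gives < 1000 nM as a limit and not as a number. The same holds for compound 1, so the pair stands at the limit of < 1000 nM in this assay, at which 2 of the 2 values shown sit, and cannot be ranked. Going by the values given here, the one measured step is a step that the two limits leave unreadable from compound 1 to compound 2 and so offers no size to carry forward.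

Compound 3 `Cc1c(COc2cccc(OCC3CCOCC3)c2)[nH]c2ccc(C(=O)O)cc2c1=O` has carboxy in place of bromo on an aromatic carbon (the full count of the change: carboxy in place of bromo on an aromatic carbon). With no readable step behind it, the expectation rests on this structural change alone and is therefore a loose one. In this assay a rise is expected, with the estimated step of an at least 20-fold higher number from compound 2 to compound 3 (1.30 log units; beyond the scatter) lying beyond the usual scatter, though another limit remains possible. For compound 3 the estimated value is 20000 nM with an expected range from 1500 nM to 150000 nM in this read-out.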

Compound 3, solubility: >= 100000 nM
Compound 3 gave a limit, no number; the forecaster's own chance of this, stated with the estimate: 25%; middle value at least 5.0-fold (0.69 log units) from the limit.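

In this assay, the place on the aromatic carbon of the six-membered ring of carbon only turns out to be one where a single change can carry the read-out far from where it stood: carboxy in place of bromo gives an at least 100-fold higher number from compound 2 to compound 3 (2.00 log units; beyond the scatter) and carboxy in place of methyl gives an at least 100-fold higher number from compound 1 to compound 3 (2.00 log units; beyond the scatter) with the rest of the molecule unchanged. Compound 3 gives >= 100000 nM and this is a limit, not a number, so both steps have a floor but no known full size. The earlier step, bromo in place of methyl, gave no such view and cannot be read, because compound 1 and compound 2 share one limit: the limit of < 1000 nM in this assay, at which 2 of the 3 values shown sit.

The compounds shown leave open whether carboxy is special at this place or whether an amine or a primary amide there would also leave the lower limit. They also leave open how a longer chain ending in carboxy would compare, and whether the same change would carry over to a core with a different ether side chain.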